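A few compounds are considered here, and "the series" means these few. Any claim that something is new, unique, unknown or untested is made for them only; others in the source may bear on it.

Compound 1 `O=C(OCCc1ccccc1)N(c1ccccc1)C1CN2CCC1CC2` gives 260 nM.
Compound 2 `COc1ccc(COC(=O)N(c2ccccc2)C2CN3CCC2CC3)cc1OC` gives 550 nM.
Compound 3 `Cc1ccc(COC(=O)N(c2ccccc2)C2CN3CCC2CC3)cc1F` gives 30 nM.

All three share the same core and differ only in the group on the ester side. In an assay on CHO cells for displacement of a labelled ligand from muscarinic acetylcholine receptor M5 (Homo sapiens), read by scintillation counting, with a stated time of 2 h (on this read-out higher numbers stand for weaker inhibition and lower numbers for stronger inhibition), compound 1 stands second highest of the three numbers: compound 2 sits above it by a margin beyond the scatter, and compound 3 sits below it by a larger margin, also beyond the scatter. Compound 4 `O=C(OCCCc1ccc(Cl)c(Cl)c1)N(c1ccccc1)C1CN2CCC1CC2` has not yet been measured. It differs from compound 1 by 3,4-dichlorobenzyl in place of phenyl on a saturated chain carbon, two bonds along the chain from an oxygen next to a carbonyl group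

Among the compounds with values here, the one measured step that bears on this is an 8.7-fold lower number from compound 1 to compound 3 (0.94 log units; beyond the scatter), in which a ring carrying two small substituents replaced a plain benzyl on a saturated chain carbon bound to an oxygen next to a carbonyl group. The change to compound 4 likewise adds a substituted ring, but also lengthens the chain, and compound 2, which carries a differently substituted benzyl, gives 550 nM, a higher number than compound 1. Within the data shown here, the direction expected is therefore downward, but with less confidence than the single step alone would suggest. Compound 4 is expected to give 120 nM, within a range of 40 nM to 400 nM. This estimate means a 2.2-fold lower number from compound 1 to compound 4 (0.34 log units; beyond the scatter), expected because an 8.7-fold lower number from compound 1 to compound 3 (0.94 log units; beyond the scatter) points the same way.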

Compound 4, inhibition constant: 130 nM
Beside the measured number, compound 4's estimate is 1.1-fold (0.03 log units) below it; low and high end bracket the measured number.
By their numbers in this assay, from the lowest: compound 3; then compounds 4 and 1 (each within the scatter of the next); then compound 2.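

In this assay the saturated chain carbon two bonds along the chain from an oxygen next to a carbonyl group takes 3,4-dichlorobenzyl in place of phenyl, with 9 heavy atoms entering where 6 leave, and the result is a 2.0-fold lower number from compound 1 to compound 4 (0.30 log units; within the scatter) and so no change that can be told from repeat measurement. The earlier step, an 8.7-fold lower number from compound 1 to compound 3 (0.94 log units; beyond the scatter), lay at a different place, on a saturated chain carbon bound to an oxygen next to a carbonyl group, and the new step does not repeat a change of that size. Nothing available here explains this outcome.

The compounds shown leave open whether a single chlorine or a plain benzyl at this place would read the same, which would separate the ring substituents from the longer chain. They also leave open how an amine or a carboxylic acid at this place would read in this assay.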